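The source may report more compounds than this note shows. Statements on the series, on what has been measured and on what is new or still open speak of the compounds shown alone.

Compounds measured so far:
Compound 1, `CCCCc1cc2ccccc2nc1-c1cc(-c2ccccc2)no1` — in a functional assay on MDA-MB-231 cells (Homo sapiens) for inhibition, read by MTT assay, with a stated time of 24 h (on this read-out lower numbers stand for stronger inhibition and higher numbers for weaker inhibition), compound 1 gives > 100000 nM, a limit of the assay rather than a number.
Compound 2, `CCCc1cc2ccccc2nc1-c1cc(-c2ccc(C)cc2)no1` — in this assay compound 2 gives > 100000 nM, again a limit and not a number.

Compound 2 therefore stands at the edge of what this assay can report: both values shown sit at the limit of > 100000 nM in this assay, at which 2 of the 2 values shown sit, so no ordering between compound 1 and compound 2 can be read from them.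

The step from compound 2 leads to compound 3, `CCCCc1cc2ccccc2nc1-c1cc(-c2ccc(C)cc2)no1`, which has not yet been measured in this assay. The change is methyl in place of hydrogen on a saturated chain carbon, three bonds along the chain from an aromatic carbon. Within the data shown here, no measured pair in this set shows what such a chain extension does here, and the only neighbours, compound 1 and compound 2, both sit at the limit. The step expected for a step that the limit leaves unreadable from compound 2 to compound 3 is accordingly none beyond the scatter, in either direction. Compound 3 is expected to give 200000 nM, within 60000 nM to 1000000 nM, most likely reported again only as a limit.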

Compound 3, half-maximal inhibitory concentration: > 100000 nM
Compound 3: no number, only a limit (the forecaster's own chance of this, stated with the estimate: 85%); the middle value does not contradict the limit.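

In this assay compound 3 gives > 100000 nM, a limit and not a number. No step among compound 1, compound 2 and compound 3 can be read from these results: the limit of > 100000 nM in this assay, at which 3 of the 3 values shown sit.

The compounds shown leave open whether either methyl change alters inhibition at all.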